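The compounds below may be only part of what the source reports. "The series", "measured", "known", "first", "only" and "open" are said of these compounds alone.

Measured so far in a functional assay on CHO cells with metabotropic glutamate receptor 2 (Homo sapiens) as the target, read by GTPgammaS binding; a higher number here means a larger maximal response, a lower number a smaller maximal response:
compound 1 `CCCc1cnc2c(C#N)c(N3CCN(c4ccccc4)CC3)ccn12` gives 241%
compound 2 `CCc1cnc2c(C#N)c(N3CCN(c4ncccn4)CC3)ccn12` gives 214%
compound 3 `Cc1cc(C)nc(N2CCN(c3ccn4c(CC(F)(F)F)cnc4c3C#N)CC2)n1` gives 128%

Compound 3 stands lowest of the three. Compound 2 sits well above it, by a gap that is beyond the scatter, and compound 1 sits higher still, also beyond the scatter. Compound 4 `CCCc1cnc2c(C#N)c(N3CCN(c4nc(C)cc(C)n4)CC3)ccn12` has not yet been measured in this assay. It differs from compound 3 in one place: ethyl in place of trifluoromethyl on a saturated chain carbon bound to an aromatic carbon. Within the data shown here, no measured pair shows this single change on its own, so the size of the step is uncertain. Because compound 3 gives 128% and the other two values are higher, an increase beyond the scatter is expected, as a number 47 percentage points higher from compound 3 to compound 4 (beyond the scatter). Compound 4 is estimated to reach 175%, expected between 120% and 235%.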

Compound 4, largest response reached (Emax), in percent of the reference or control that the assay uses: 179%
For compound 4 the middle estimate is 4 percentage points below the measured one, and the stated range covers the measured number.
By their numbers in this assay, from the lowest: compound 3; then compound 4; then compound 2; then compound 1.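

With the 4,6-dimethylpyrimidin-2-yl group held fixed, changing 2,2,2-trifluoroethyl to propyl in this assay gives a number 51 percentage points higher from compound 3 to compound 4 (beyond the scatter), the first single change read at this position. With propyl held fixed, 4,6-dimethylpyrimidin-2-yl in place of phenyl on an amine nitrogen in a ring gives a number 62 percentage points lower from compound 1 to compound 4 (beyond the scatter), so both places on the molecule can move the maximal response. No supporting data explain either step. As far as these compounds go, whether a longer chain such as butyl would raise the response further remains open. So does the effect of the same trifluoroethyl-to-propyl change when phenyl is present.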